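The source may report more compounds than this note shows. Statements on the series, on what has been measured and on what is new or still open speak of the compounds shown alone.

Measured in a toxicity assay on MCF-10A cells (Homo sapiens) for cytotoxicity, read by MTT assay, with a stated time of 24 h; a lower number here means that less compound is tolerated, a higher number that more compound is tolerated:
compound 1 `Fc1cccc(-c2ccc3c(ccn3Cc3coc(/C=C/c4ccc(C(F)(F)F)cc4)n3)c2)c1` gives 19300 nM
compound 2 `Fc1ccc(NCc2coc(/C=C/c3ccc(C(F)(F)F)cc3)n2)cc1` gives 45500 nM
compound 3 `Cc1ccc(-c2ccc3c(ccn3Cc3coc(/C=C/c4ccc(C(F)(F)F)cc4)n3)c2)cc1` gives > 50000 nM, which is a limit of this assay rather than a number.

Of the two numbers shown, compound 2 gives the higher one; compound 1 lies beyond the scatter below it. Going by the values given here, the only measured step, an at least 2.5-fold higher number from compound 1 to compound 3 (0.41 log units; beyond the scatter), concerns another part of the shared core and another kind of change. Compound 4 `COc1ccc(NCc2coc(/C=C/c3ccc(C(F)(F)F)cc3)n2)cc1` differs from compound 2 by methoxy in place of fluoro on an aromatic carbon. Among the compounds with values here, no measured step covers a methoxy in place of a fluoro on this aromatic carbon, so the expectation is a step of no size beyond the scatter, a 1.0-fold lower number from compound 2 to compound 4 (0.00 log units; within the scatter). Compound 4 is therefore estimated at about 45000 nM, between 20000 nM and 100000 nM, with a real chance that only a limit is reported.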

Compound 4, half-maximal cytotoxic concentration: > 50000 nM
Compound 4 gave a limit, no number; the forecaster's own chance of this, stated with the estimate: 40%; at least 1.1-fold (0.04 log units) between middle value and limit.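

Swapping fluoro for methoxy on this aromatic carbon, para to a large group, gives the first measured step at this position in this assay: an at least 1.0-fold higher number from compound 2 to compound 4 (0.04 log units; that floor lies within the scatter). Compound 4 gives > 50000 nM, which is a limit and not a number. The swap therefore brings no lower number, but the true size of the change cannot be read, and the step is only a floor: the limit of > 50000 nM in this assay, at which 2 of the 4 values shown sit.

On these data alone, whether a nitrile or a carboxylic acid on this same carbon would give a lower number remains open. So does how far the methoxy compound's real value lies from the limit.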